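Working notes: cytotoxicity of a 4-sulfamoylphenyl series

This account rests on a few compounds, and the source may have more. Where it says the series, first, only, none or still open, it means among the compounds named here.

Compound 1 `Cc1ccc(C(=O)NC2=C(C#N)C(c3ccc(Cl)cc3Cl)C3=C(CCCC3=O)N2c2ccc(S(N)(=O)=O)cc2)cc1`: in a functional assay on Ehrlich cells (Mus musculus) for cytotoxicity, read by trypan blue exclusion, with a stated time of 2 h (on this read-out higher numbers stand for weaker inhibition and lower numbers for stronger inhibition), compound 1 gives > 100 ug/mL, which is a limit of the assay and not a number.
Compound 2 `N#CC1=C(NC(=O)c2ccc([N+](=O)[O-])cc2)N(c2ccc(S(N)(=O)=O)cc2)C2=C(C(=O)CCC2)C1c1ccc(Cl)cc1Cl`: in this assay compound 2 gives 50 ug/mL.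

Compound 2 holds the only number shown; the other value is a limit. Among the measured compounds shown here, the one measured step, an at least 2.0-fold lower number from compound 1 to compound 2 (0.30 log units; that floor lies within the scatter), reaches only a floor, resting on (the limit of > 100 ug/mL in this assay, at which 1 of the 2 values shown sits). Compound 3 `CN(C)c1ccc(/C=N/C2=C(C#N)C(c3ccc(Cl)cc3Cl)C3=C(CCCC3=O)N2c2ccc(S(N)(=O)=O)cc2)cc1` differs from compound 2 by a group of 11 heavy atoms (9 carbon, 2 nitrogen; one six-membered aromatic ring of carbon only) in place of a group of 12 heavy atoms (7 carbon, 2 nitrogen, 3 oxygen; one six-membered aromatic ring of carbon only), on a double-bonded ring carbon. For the measured compounds named here, no measured step touches this exchange, so no shift beyond the scatter is expected. Compound 3 is expected to give 60 ug/mL, between 25 ug/mL and 150 ug/mL, the expected step being a 1.2-fold higher number from compound 2 to compound 3 (0.08 log units; within the scatter).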

Compound 3, half-maximal inhibitory concentration: > 100 ug/mL
Compound 3 ended at the assay's limit; the forecaster's own chance of this, stated with the estimate: 35%; at least 1.6-fold (0.22 log units) between middle value and limit.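

At this double-bonded ring carbon, replacing ((4-nitrophenyl)carbonyl)amino with the entering group, which has 0 hydrogen-bond donors, gives an at least 2.0-fold higher number from compound 2 to compound 3 (0.30 log units; that floor lies within the scatter). The step from compound 1 to compound 3 cannot be read, since both values are limits. Of the three groups at this carbon, only ((4-nitrophenyl)carbonyl)amino gives a number in this assay, and the other two readings end at a limit: the limit of > 100 ug/mL in this assay, at which 2 of the 3 values shown sit.

Still open, as far as these compounds go, is whether a ((4-aminophenyl)carbonyl)amino or ((4-carboxyphenyl)carbonyl)amino group at this carbon would give a number in this assay or end at the limit.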